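The source may hold more compounds than are shown below. What is called first, only, known or untested is meant among the compounds shown, and "the series" means these compounds.

Three compounds share one core and differ only in the group on an amine nitrogen. In a physicochemical assay for lipophilicity (a higher number here means a more lipophilic compound, a lower number a more polar compound), compound 1 `CCOC(=O)C1=C(C)NC(=O)NC1c1cn(C(=O)CNc2ccc([N+](=O)[O-])cc2C)c2ccccc12` gives 1.94, compound 2 `CCOC(=O)C1=C(C)NC(=O)NC1c1cn(C(=O)CNc2ccccc2[N+](=O)[O-])c2ccccc12` gives 1.48, and compound 3 `CCOC(=O)C1=C(C)NC(=O)NC1c1cn(C(=O)CNc2cccc([N+](=O)[O-])c2)c2ccccc12` gives 1.48. Compound 3 therefore stands level with compound 2 at the digits shown, the two together being the lowest of the three numbers, while the step of a number 0.46 log units lower from compound 1 to compound 3 (beyond the scatter) lies beyond the scatter. Compound 4 `CCOC(=O)C1=C(C)NC(=O)NC1c1cn(C(=O)CNc2ccc([N+](=O)[O-])cc2)c2ccccc12` carries 4-nitrophenyl in place of 3-nitrophenyl on an amine nitrogen. The step closest in kind, no change at the digits printed from compound 2 to compound 3 (within the scatter), stayed within the scatter; the step of a number 0.46 log units lower from compound 1 to compound 2 (beyond the scatter) also dropped a methyl group, so it bears less on this change. The expected step of a number 0.07 log units higher from compound 3 to compound 4 (within the scatter) is thus within the scatter. Compound 4 is estimated at 1.55 in this assay, ranging from 1.25 to 1.85.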

Compound 4, partition coefficient: 1.48
Beside the measured number, compound 4's estimate is 0.07 log units above it; measured number inside the range.
By their numbers in this assay, from the lowest: compounds 2, 3 and 4 (each within the scatter of the next); then compound 1.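

Putting 4-nitrophenyl on the amine nitrogen gives no change at the digits printed from compound 3 to compound 4 (within the scatter) and also no change at the digits printed from compound 2 to compound 4 (within the scatter) in this assay so the 2-nitrophenyl, 3-nitrophenyl and 4-nitrophenyl groups read alike there. Hydrogen in place of methyl on an aromatic carbon, with nothing else changed, gives a number 0.46 log units lower from compound 1 to compound 4 (beyond the scatter) and this is the first step beyond the scatter that involves the methyl alone, with the nitro group staying where it is. From the compounds shown here alone, whether an amine or a carboxylic acid in place of the nitro group would give the same reading remains open. Nothing measured here explains these results.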